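The source may hold more compounds than are shown below. What is called first, only, known or untested is meant among the compounds shown, and "the series" means these compounds.

Measured compounds:
compound 1 `CN(C(=O)NC(=O)c1ccc(Cl)cc1Cl)c1nc(C(F)(F)F)c(C(=O)N/N=C/c2ccc(C(F)(F)F)cc2)s1` — 7.99 ug/mL
compound 2 `CN(C(=O)NC(=O)c1c(F)cccc1F)c1nc(C(F)(F)F)c(C(=O)N/N=C/c2cccc(C(F)(F)F)c2)s1` — 21.6 ug/mL
compound 3 `CN(C(=O)NC(=O)c1ccc(C(F)(F)F)cc1)c1nc(C(F)(F)F)c(C(=O)N/N=C/c2ccc(C(F)(F)F)cc2)s1` — > 100 ug/mL

Compound 3, `CN(C(=O)NC(=O)c1ccc(C(F)(F)F)cc1)c1nc(C(F)(F)F)c(C(=O)N/N=C/c2ccc(C(F)(F)F)cc2)s1`, stands at the weak end of the three measured compounds in a functional assay on HeLa cells (Homo sapiens) for inhibition, read by MTT assay, with a stated time of 72 h; a higher number here means a weaker inhibitor, a lower number a stronger inhibitor. Its value, > 100 ug/mL, is a limit of this assay rather than a number (the limit of > 100 ug/mL in this assay, at which 1 of the 3 values shown sits). Compound 1 gives 7.99 ug/mL in this assay and compound 2 gives 21.6 ug/mL. For the measured compounds named here, the one measured step that touches compound 3 is an at least 12-fold higher number from compound 1 to compound 3 (1.09 log units; beyond the scatter), a change on the same carbonyl carbon that the new compound alters.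

Compound 4, `CN(C(=O)NC(=O)c1c(F)cccc1F)c1nc(C(F)(F)F)c(C(=O)N/N=C/c2ccc(C(F)(F)F)cc2)s1`, carries 2,6-difluorophenyl in place of 4-(trifluoromethyl)phenyl on a carbonyl carbon. The step of an at least 12-fold higher number from compound 1 to compound 3 (1.09 log units; beyond the scatter) shows that exchanging the ring on this carbonyl carbon can move this assay by a large amount, so the reverse direction, away from the 4-(trifluoromethyl)phenyl group, is expected to lower the number again. Compound 4 shares its 2,6-difluorophenyl group with compound 2 but differs from it elsewhere. Compound 2 gives 21.6 ug/mL, a number rather than a limit. Compound 4 is therefore estimated to show a step of an at least 5.0-fold lower number from compound 3 to compound 4 (0.69 log units; beyond the scatter), landing at 20 ug/mL, with a range from 6 ug/mL to 70 ug/mL.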

Compound 4, half-maximal inhibitory concentration: 30.6 ug/mL
Estimate against measurement, compound 4: 1.5-fold (0.18 log units) below; the measured number falls inside the stated range.
By their numbers in this assay, from the lowest: compound 1; then compounds 2 and 4 (each within the scatter of the next). At a limit, above all of these: compound 3.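

In this assay, the exchange of 4-(trifluoromethyl)phenyl for 2,6-difluorophenyl on this carbonyl carbon returns the series from a limit to a measured number (an at least 3.2-fold lower number from compound 3 to compound 4 (0.51 log units; beyond the scatter)), so the large step seen earlier does not apply to every ring that replaces 2,4-dichlorophenyl here. The 2,6-difluorophenyl group does not match the 2,4-dichlorophenyl group, however, and that exchange carries a modest cost (a 3.8-fold higher number from compound 1 to compound 4 (0.58 log units; beyond the scatter)), which places this carbonyl position as one where the pattern on the ring matters in graded steps rather than all at once. For the compounds shown here, compound 4 also adds the first reading at the other position, on the carbon with a double bond to nitrogen, where exchanging 3-(trifluoromethyl)phenyl for 4-(trifluoromethyl)phenyl with 2,6-difluorophenyl held constant stays within the scatter (a 1.4-fold higher number from compound 2 to compound 4 (0.15 log units; within the scatter)).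

From the compounds shown here alone, whether an amine or a carboxylic acid could take the place of the aromatic ring on this carbonyl carbon remains open. Going by these compounds, the true distance of compound 3 from the other compounds also remains open, because its value is a limit and not a number: the limit of > 100 ug/mL in this assay, at which 1 of the 4 values shown sits.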